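Dichlorophenyl Variant of a Series at the Assay Limit

The source may report more compounds than this note shows. Statements on the series, on what has been measured and on what is new or still open speak of the compounds shown alone.

The study examines three compounds that share one core and differ only in the substituted phenyl ring carried on an aromatic nitrogen. Compound 1, `N#CC1=C(N)Oc2c(c3nc4ccccc4nc3c3ccccc23)C12C(=O)N(Cc1cnnn1-c1ccc(Cl)cc1)c1ccccc12`, was tested in a functional assay on HepG2 cells (Homo sapiens) for antiproliferative activity, read by MTT assay, with a stated time of 48 h; on this read-out higher numbers stand for weaker inhibition and lower numbers for stronger inhibition. In this assay compound 1 returns only a limit of the assay, > 50000 nM. Compound 2, `N#CC1=C(N)Oc2c(c3nc4ccccc4nc3c3ccccc23)C12C(=O)N(Cc1cnnn1-c1ccccc1Cl)c1ccccc12`, was tested in the same way. In this assay compound 2 likewise returns only a limit, > 50000 nM. The step that the two limits leave unreadable from compound 1 to compound 2 cannot be read, since both values sit at the limit of > 50000 nM in this assay, at which 2 of the 2 values shown sit. For the measured compounds named here, compound 2 therefore stands at the upper edge of what this assay reports, alongside the only other value shown.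

Compound 3, `N#CC1=C(N)Oc2c(c3nc4ccccc4nc3c3ccccc23)C12C(=O)N(Cc1cnnn1-c1ccc(Cl)c(Cl)c1)c1ccccc12`, is the next variant. The change from compound 2 is 3,4-dichlorophenyl in place of 2-chlorophenyl on an aromatic nitrogen. Going by the values given here, the only measured step that bears on it, the one from compound 1 to compound 2, has no readable size, so there is no measured basis for expecting movement in either direction. Compound 3 is accordingly expected to show a step of a number no higher from compound 2 to compound 3 (the limit leaves the size open), that is, none beyond the scatter. Compound 3 is estimated at 50000 nM, in the range 15000 nM to 200000 nM, most probably again as a limit.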

Compound 3, half-maximal inhibitory concentration: > 50000 nM
Compound 3 ended at the assay's limit; the forecaster's own chance of this, stated with the estimate: 80%; the middle value lies on the limit itself.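

In this assay compound 3 also returns only a limit, > 50000 nM. No step among compound 1, compound 2 and compound 3 can be read, since all three values sit at the same edge: the limit of > 50000 nM in this assay, at which 3 of the 3 values shown sit.

The compounds shown leave open whether the chlorine pattern on the phenyl ring makes any difference to activity in this assay.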